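This account rests on a few compounds, and the source may have more. Where it says the series, first, only, none or still open, it means among the compounds named here.

Compound 1 `COc1ccc(-c2cc(=O)c3c(OC)cc(OC)cc3[nH]2)cc1` is the point of departure. In an ADME assay on BJ cells (Homo sapiens) for antiproliferative activity, with a stated time of 72 h (on this read-out lower numbers stand for an effect already at smaller amounts and higher numbers for an effect only at larger amounts of compound), compound 1 gives > 62000 nM, which is a limit of the assay and not a number. Two related compounds were measured alongside it. Compound 2 `COc1ccc(-c2cc(=O)c3c(OC)cc(OC)cc3n2S(=O)(=O)c2ccc([N+](=O)[O-])cc2)cc1` gives > 29300 nM in this assay, again only a limit. Compound 3 `COc1ccc(-c2cc(=O)c3c(OC)cc(OC)cc3n2S(=O)(=O)c2ccc(C#N)cc2)cc1` gives > 17200 nM in this assay, also a limit. The two steps that change one place at a time are therefore not readable: a step that the two limits leave unreadable from compound 1 to compound 3 and a step that the two limits leave unreadable from compound 2 to compound 3 both rest on pairs of limits, so neither their size nor their direction can be stated.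

Compound 4 `COc1ccc(-c2cc(=O)c3c(OC)cc(OC)cc3n2S(=O)(=O)Cc2ccccc2)cc1` differs from compound 1 by the change (benzylsulfonyl in place of hydrogen on an aromatic nitrogen). Because the limit of > 62000 nM in this assay, at which 1 of the 3 values shown sits, and the limit of > 17200 nM in this assay, at which 1 of the 3 values shown sits, frame the step from compound 1 to compound 3 without a number, no readable step is available to carry over, and no effect beyond the scatter can be read from it. Compound 4 is expected to give about 50000 nM in this assay, within a range of 15000 nM to 150000 nM. That estimate means an expected step of an at least 1.2-fold lower number from compound 1 to compound 4 (0.09 log units; that floor lies within the scatter), most likely reported only as a further limit.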

Compound 4, half-maximal effective concentration: > 34400 nM
Compound 4 ended at the assay's limit; the forecaster's own chance of this, stated with the estimate: 85%; the middle value does not contradict the limit.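

In this assay compound 4 gives > 34400 nM, which is a limit and not a number. Its steps from compound 1, compound 2 and compound 3 all rest on pairs of limits, so none can be read. The compounds shown leave open at what concentration any of them would act on these cells, and whether the group on the sulfonyl sulfur alters that.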